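Dimethylamino in Place of Phenoxy: an Expected Cytotoxicity Value

A few compounds are considered here, and "the series" means these few. Any claim that something is new, unique, unknown or untested is made for them only; others in the source may bear on it.

Measured compounds:
compound 1, `COc1cc(C)cc(-c2c(-c3ccnc(-c4ccc(C(C)=O)cc4)c3)cnn2CC#N)c1`: 71%
compound 2, `Cc1cc(O)cc(-c2nn(CC#N)cc2-c2ccnc(-c3ccc(Oc4ccccc4)cc3)c2)c1`: 82%

In a functional assay on Hs-578T cells (Homo sapiens) for cytotoxicity, read by sulforhodamine B assay, with a stated time of 48 h, tested at 100 nM (a lower number here means a stronger effect, a higher number a weaker effect of the compound at the concentration tested), compound 2 gives 82%, the highest of the two numbers at hand. Compound 1 gives 71%, a number lower by a difference that lies beyond the usual scatter of this measurement. Among the measured compounds shown here, the two measured compounds differ in more than one place, so no single-point step is known from them.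

Compound 3 `Cc1cc(O)cc(-c2nn(CC#N)cc2-c2ccnc(-c3ccc(N(C)C)cc3)c2)c1` has not yet been measured. It differs from compound 2 in one place only: dimethylamino in place of phenoxy on an aromatic carbon. For the measured compounds named here, no measured pair shows what such a change does here, so the expected step is small and without a clear direction; a move within the scatter is the most likely outcome, though a larger shift either way cannot be ruled out. The step estimated for this change is a number 2 percentage points lower from compound 2 to compound 3 (within the scatter). For compound 3 the expected value is 80%, with a range from 62% to 96%.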

Compound 3, a percentage reported as activity, at one concentration (the size of the read-out at that concentration, not a potency): 82%
Compound 3: the middle estimate sits 2 percentage points below what was measured; the range from low to high includes it.
By their numbers in this assay, from the lowest: compound 1; then compounds 2 and 3 (each within the scatter of the next).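

Among the compounds shown here, replacing phenoxy with dimethylamino on this aromatic carbon, para to a large group, gives the first single-place step: in this assay the change leaves no change at the digits printed from compound 2 to compound 3 (within the scatter). The exchange removes the six-membered aromatic ring of carbon only and goes from 7 heavy atoms to 3, yet the read-out stays within the scatter, so at this concentration this position tolerates this particular swap. No available evidence explains this result.

The compounds shown leave open whether this tolerance extends to groups of other kinds at the same position, such as a carboxylic acid, a primary amine or a longer chain like diethylamino. They also leave open whether the two groups would remain alike at a concentration other than the one tested here.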